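Cytotoxicity in the stilbene-terpene series: methoxy to arylamino

A few compounds are considered here, and "the series" means these few. Any claim that something is new, unique, unknown or untested is made for them only; others in the source may bear on it.

The series is followed in an ADME assay on HEK293 cells (Homo sapiens) for cytotoxicity, with a stated time of 72 h; a lower number here means that less compound is needed, a higher number that more compound is needed for the effect. Compound 1 `C=C[C@@](C)(/C=C/c1ccc(OC)cc1)CCC=C(C)C` gives only a limit in this assay: > 36600 nM is a limit, not a number. Compound 2 `C=C[C@@](C)(/C=C/c1ccc(O)cc1)CC/C=C(C)/C=C/C(=O)OCc1ccccc1` also gives only a limit, > 36600 nM. Among the compounds with values here, both values therefore sit at the limit of > 36600 nM in this assay, at which 2 of the 2 values shown sit, and compound 1 stands at the same limit as the one other compound measured, so no ordering among the measured compounds can be drawn.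

Compound 3 `C=C[C@@](C)(/C=C/c1ccc(Nc2ccc(Cl)cc2)cc1)CCC=C(C)C` differs from compound 1 by (4-chlorophenyl)amino in place of methoxy on an aromatic carbon. Within the data shown here, no step between measured compounds is recorded that would show how such a change moves this assay. The expected step is from compound 1 to compound 3 an at least 2.4-fold lower number from compound 1 to compound 3 (0.38 log units; beyond the scatter), a drop beyond the scatter, though with wide uncertainty since the starting point is only a limit. Compound 3 is therefore estimated at 15000 nM in this assay, in the range 4000 nM to 40000 nM, with a fair chance that only a limit is reported again.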

Compound 3, half-maximal effective concentration: > 36600 nM
Compound 3: a limit, no number (the forecaster's own chance of this, stated with the estimate: 40%); middle value at least 2.4-fold (0.38 log units) away from the limit.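

The step from compound 1 to compound 3 cannot be read, because both give only a limit, not a number: the limit of > 36600 nM in this assay, at which 3 of the 3 values shown sit.

The compounds shown leave open whether (4-chlorophenyl)amino in place of methoxy on an aromatic carbon moves this assay at all, and how the three compounds order.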